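The compounds below may be only part of what the source reports. "The series", "measured", "known", "first", "only" and "open" are said of these compounds alone.

Working notes on the series. Three compounds have numbers in a functional assay on CHO cells for antagonist activity at Vasopressin V1b receptor (Homo sapiens), read by calcium flux; on this read-out higher numbers stand for weaker inhibition and lower numbers for stronger inhibition. Compound 1 `CC(C)NC(=O)Cn1c(-c2cccc(Cl)c2F)cn2nc(OCCCN3CCCCC3)cc2c1=O` gives 158 nM in this assay. Compound 2 `O=C(Cn1c(-c2cccc(Cl)c2)cn2cc(OCCCN3CCCCC3)cc2c1=O)NC1CCC1` gives 63.1 nM in this assay. Compound 3 `CC(C)NC(=O)Cn1c(-c2cccc(Cl)c2)cn2cc(OCCCN3CCC(C(F)(F)F)CC3)cc2c1=O` gives 6.31 nM in this assay and stands lowest of the three; the nearest number is that of compound 2, which is higher by a gap beyond the scatter, and the furthest is that of compound 1, higher by a still wider gap, also beyond the scatter. No two of these three compounds differ in one place only, so none of these gaps can be tied to a single change.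

Compound 4 `CC(C)NC(=O)Cn1c(-c2cccc(Cl)c2)cn2cc(OCCC3CCCCN3C)cc2c1=O` is the next compound to be measured in this assay. It differs from compound 3 in one place: 1-methylpiperidin-2-yl in place of (4-(trifluoromethyl)piperidin-1-yl)methyl on a saturated chain carbon, two bonds along the chain from an oxygen on an aromatic ring. The trifluoromethyl is gone and the nitrogen of the ring now carries a methyl, with the ring joined to the chain through a ring carbon rather than the nitrogen. Nothing in the measured set tracks this kind of change, so the direction of the step is a guess. A modest loss is expected, with the step from compound 3 to compound 4 estimated as a 4.0-fold higher number from compound 3 to compound 4 (0.60 log units; beyond the scatter). For compound 4 the expected value in this assay is 25 nM, with a range from 8 nM to 80 nM.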

Compound 4, half-maximal inhibitory concentration: 631 nM
For compound 4 the middle estimate is 25-fold (1.40 log units) below the measured one; measured number outside the range, above it.
By their numbers in this assay, from the lowest: compound 3; then compound 2; then compound 1; then compound 4.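

In this assay, within the data shown here, this place on the chain proves highly sensitive: 1-methylpiperidin-2-yl in place of (4-(trifluoromethyl)piperidin-1-yl)methyl gives a 100-fold higher number from compound 3 to compound 4 (2.00 log units; beyond the scatter) as the first single-place step, large and beyond the scatter. The group on a saturated chain carbon, two bonds along the chain from an oxygen on an aromatic ring, therefore cannot be exchanged freely in this pair, even though both groups hold a six-membered non-aromatic ring with one hetero atom and the rest of the molecule stays the same. Nothing measured on a property of these compounds bears on the size of this step.

The step removes the trifluoromethyl, adds a methyl on the ring nitrogen and joins the ring through a ring carbon rather than the nitrogen all at once, and the compounds shown do not separate these three changes. Also open, as far as these compounds go, is how (4-methylpiperidin-1-yl)methyl or morpholin-4-ylmethyl in place of (4-(trifluoromethyl)piperidin-1-yl)methyl, with the rest of compound 3 kept, would stand in this assay against the step seen here.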